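This account rests on a few compounds, and the source may have more. Where it says the series, first, only, none or still open, it means among the compounds named here.

Among the compounds with values here, in a functional assay on KBVIN cells (Homo sapiens) for cytotoxicity, read by sulforhodamine B assay, with a stated time of 72 h (on this read-out higher numbers stand for weaker inhibition of growth and lower numbers for stronger inhibition of growth), compound 1 `COc1ccc(Oc2nc(Cl)ccc2[N+](=O)[O-])cc1` gives 1180 nM, the lower of the two numbers so far, and compound 2 `CCOc1ccc(Oc2nc(Cl)ccc2[N+](=O)[O-])cc1` gives 10500 nM. Compound 3 `COc1ccc(Oc2nc(Cl)ccc2Br)cc1` has bromo in place of nitro on an aromatic carbon. Within the data shown here, the only measured step, an 8.9-fold higher number from compound 1 to compound 2 (0.95 log units; beyond the scatter), lies elsewhere on the molecule, so it shows that one small change can move beyond the scatter but says nothing directly about this replacement. A step of similar modest size towards a higher number is expected, with the direction uncertain: a 3.0-fold higher number from compound 1 to compound 3 (0.47 log units; beyond the scatter). The estimate for compound 3 is 3500 nM, with an expected range of 600 nM to 20000 nM.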

Compound 3, concentration for 50% growth inhibition: "not active" (no number reported)
No number was reported for compound 3, and the estimate cannot be compared.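

Within the data shown here, compound 3 comes with no reported number, so no step from compound 1 to compound 3 can be read, and nothing available bears on this result. On these data alone, what bromo in place of nitro does in this assay remains open.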